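From chloro to phenyl: an analogue still to be tested

This account rests on a few compounds, and the source may have more. Where it says the series, first, only, none or still open, it means among the compounds named here.

Of the compounds shown here, two sharing one core have so far been tested in a functional assay on UACC-62 cells (Homo sapiens) for inhibition, read by sulforhodamine B assay, with a stated time of 48 h, tested at 10 uM; a lower number here means less inhibition of growth, a higher number more inhibition of growth at the concentration tested. Compound 1 `CC(=O)c1cccc(Nc2ccnc(SCC(=O)c3ccc(-c4ccccc4)cc3)n2)c1` gives 24% in this assay. Compound 2 `CC(=O)c1ccc(Nc2ccnc(SCC(=O)c3ccc(Cl)cc3)n2)cc1` gives 34% in this assay. For the measured compounds named here, these two numbers lie within the usual scatter of each other, so the data do not separate compound 2 from compound 1, its only neighbour.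

Compound 3 `CC(=O)c1ccc(Nc2ccnc(SCC(=O)c3ccc(-c4ccccc4)cc3)n2)cc1` has not yet been measured in this assay. Compared with compound 2, the change is phenyl in place of chloro on an aromatic carbon. Going by the values given here, no measured pair differs in exactly this way, so there is no measured step to lean on. The same phenyl group is present in compound 1, whose number sits within the scatter of compound 2. The step is therefore expected to stay within the scatter, in no particular direction. Compound 3 is expected to give 30% in this assay, within 15% to 45%, an expected step of a number 4 percentage points lower from compound 2 to compound 3 (within the scatter).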

Compound 3, percent growth inhibition at one concentration: 20%
Compound 3: the middle estimate sits 10 percentage points above what was measured; the range from low to high includes it.
By their numbers in this assay, from the lowest: compounds 3, 1 and 2 (each within the scatter of the next, the first and the last beyond it).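

In this assay, the change from chloro to phenyl on an aromatic carbon, para to a large group, now has a measured step of its own: a number 14 percentage points lower from compound 2 to compound 3 (beyond the scatter). This modest step is the only one among these compounds that lies beyond the scatter, and it rests on a single pair. With phenyl in place, 4-acetylphenyl in place of 3-acetylphenyl on the nitrogen gives a number 4 percentage points lower from compound 1 to compound 3 (within the scatter), so the data do not separate these two compounds, and nothing available explains either step.

With only chloro and phenyl seen at this position, the trend between them cannot be extended to other groups. Going by these compounds, whether fluoro, methoxy, an amine or a carboxylic acid on the same carbon would fall nearer compound 2 or compound 3 remains open.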